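A few compounds are considered here, and "the series" means these few. Any claim that something is new, unique, unknown or untested is made for them only; others in the source may bear on it.

Compound 1 `COc1ccc(N(Cc2noc(-c3ccccc3)n2)C(=O)CCCCCC(=O)NO)cc1`: 5190 nM
Compound 2 `COc1ccc(N(Cc2noc(-c3cccc(F)c3)n2)C(=O)CCCCCC(=O)NO)cc1`: 6560 nM

Within the data shown here, the only comparison so far in a functional assay on HCCLM3 cells (Homo sapiens) for antiproliferative activity, read by MTT assay, with a stated time of 48 h (on this read-out higher numbers stand for weaker inhibition and lower numbers for stronger inhibition), is a 1.3-fold higher number from compound 1 to compound 2 (0.10 log units; within the scatter), so compound 2 cannot be told apart from its one measured neighbour. Compound 3 `COc1ccc(N(Cc2noc(-c3cccc(C)c3)n2)C(=O)CCCCCC(=O)NO)cc1` keeps the core of compound 2 and changes one group: methyl in place of fluoro on an aromatic carbon. Among the measured compounds shown here, the single measured step that bears on this is the fluoro-for-hydrogen change on the same ring, a 1.3-fold higher number from compound 1 to compound 2 (0.10 log units; within the scatter). For the measured compounds named here, that step stayed within the scatter, but one step is thin evidence, and no methyl compound has been measured yet. On this basis, no shift beyond the scatter is expected in this assay, in either direction. The estimated change is a 1.1-fold lower number from compound 2 to compound 3 (0.05 log units; within the scatter). For compound 3 the estimated value is 5800 nM, with an expected range from 2900 nM to 11500 nM.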

Compound 3, half-maximal inhibitory concentration: 6830 nM
Compound 3: middle estimate off by 1.2-fold (0.07 log units), on the low side; measured number inside the range.
By their numbers in this assay, from the lowest: compounds 1, 2 and 3 (each within the scatter of the next).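

In this assay, replacing fluoro with methyl, a change from 3-fluorophenyl to 3-methylphenyl, gives a 1.0-fold higher number from compound 2 to compound 3 (0.02 log units; within the scatter), and methyl in place of hydrogen gives a 1.3-fold higher number from compound 1 to compound 3 (0.12 log units; within the scatter). Among these compounds, compound 1 had so far been compared only with a fluoro compound, and now two different one-atom groups on this aromatic carbon, fluoro and methyl, both stay within the scatter of hydrogen, and of each other, so compounds 1, 2 and 3 cannot be told apart. Nothing measured here offers a reason for this flat result.

From the compounds shown here alone, it remains open whether an amine, a carboxylic acid or a methoxy group at this same place would move the number beyond the scatter. Going by these compounds, the effect of a change elsewhere in the shared core, such as a longer chain, also remains open.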